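Dimethylamino to methoxy on the anilide of the shared core

This account rests on a few compounds, and the source may have more. Where it says the series, first, only, none or still open, it means among the compounds named here.

Measured so far:
compound 1 `CCc1ccc(NC(=O)c2csc(Cc3c(Cl)cccc3Cl)n2)cc1`: 1450 nM
compound 2 `CN(C)c1ccc(NC(=O)c2csc(Cc3c(Cl)cccc3Cl)n2)cc1`: 1270 nM

In an assay on CHO cells, read by calcium flux (a lower number here means a stronger inhibitor, a higher number a weaker inhibitor), compound 2 stands lowest of the two numbers, with compound 1 nearest at a gap within the scatter. Compound 3 `COc1ccc(NC(=O)c2csc(Cc3c(Cl)cccc3Cl)n2)cc1` differs from compound 2 by methoxy in place of dimethylamino on an aromatic carbon. Within the data shown here, the only step that bears on it is a 1.1-fold lower number from compound 1 to compound 2 (0.06 log units; within the scatter), which shows that a swap of this group on the same aromatic carbon left this assay unchanged. No step beyond the scatter is therefore expected here. Compound 3 is estimated at 1300 nM, range 600 nM to 2800 nM, meaning an expected step of a 1.0-fold higher number from compound 2 to compound 3 (0.01 log units; within the scatter).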

Compound 3, half-maximal inhibitory concentration: > 4000 nM
Compound 3: a limit, no number; the forecaster's own chance of this, stated with the estimate: 5%; middle value at least 3.0-fold (0.48 log units) away from the limit.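

At the aromatic carbon para to a large group, the substituent does matter in this assay: ethyl and dimethylamino lie within the scatter of each other, yet methoxy gives an at least 3.1-fold higher number from compound 2 to compound 3 (0.49 log units; beyond the scatter) and an at least 2.7-fold higher number from compound 1 to compound 3 (0.44 log units; beyond the scatter). Methoxy and dimethylamino have the same hydrogen-bond donor and acceptor counts and no net charge, so these counts do not separate compound 2 from compound 3. The value of compound 3 is a limit, not a number, so both steps give only a minimum size: the limit of > 4000 nM in this assay, at which 1 of the 3 values shown sits.

Still open, from the compounds shown here alone, is whether ethoxy or a primary amine at this carbon would track methoxy or dimethylamino.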